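A few compounds are considered here, and "the series" means these few. Any claim that something is new, unique, unknown or untested is made for them only; others in the source may bear on it.

Measured compounds:
compound 1, `Cc1cccc(OS(=O)(=O)c2ccc(N3CCN(C)C3=O)cc2)c1`, 2300 nM
compound 2, `COc1cccc(OS(=O)(=O)c2ccc(N3CCN(C)C3=O)cc2)c1`, 1600 nM
compound 3, `CCCN1CCN(c2ccc(S(=O)(=O)Oc3cccc(C)c3)cc2)C1=O`, 28000 nM

All three were tested in a functional assay on M21 cells (Homo sapiens) for antiproliferative activity, read by sulforhodamine B assay, with a stated time of 48 h; on this read-out higher numbers stand for weaker inhibition and lower numbers for stronger inhibition. Compound 1 gives 2300 nM and compound 2 gives 1600 nM; the two differ by one change, (methoxy in place of methyl on an aromatic carbon), and the result was a 1.4-fold lower number from compound 1 to compound 2 (0.16 log units; within the scatter), so the two numbers cannot be told apart. Compound 3 carries a different core: it differs from compound 1 by ethyl in place of hydrogen on a saturated chain carbon bound to an amide-type nitrogen in a ring, and this step read a 12-fold higher number from compound 1 to compound 3 (1.09 log units; beyond the scatter).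

Compound 4, `CCCN1CCN(c2ccc(S(=O)(=O)Oc3cccc(OC)c3)cc2)C1=O`, has not yet been measured. It is built from compound 3 by methoxy in place of methyl on an aromatic carbon. For the measured compounds named here, this is the same change as the one from compound 1 to compound 2, made at the same place on the same kind of ring, only on the core of compound 3. Because a 1.4-fold lower number from compound 1 to compound 2 (0.16 log units; within the scatter) stayed within the scatter, the expected step here is likewise small, a 1.3-fold lower number from compound 3 to compound 4 (0.10 log units; within the scatter). The number for compound 4 in this assay is therefore estimated at 22000 nM, with a likely range from 9000 nM to 50000 nM.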

Compound 4, half-maximal inhibitory concentration: 10000 nM
For compound 4 the middle estimate is 2.2-fold (0.34 log units) above the measured one, and the stated range covers the measured number.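

In this assay, methoxy in place of methyl on the core of compound 3 gives a 2.8-fold lower number from compound 3 to compound 4 (0.45 log units; beyond the scatter), and set beside the same change on the core of compound 1, the step carries over as far as the scatter can tell: the same change on two cores in this assay, a 1.4-fold lower number (0.16 log units; within the scatter) from compound 1 to compound 2 and a 2.8-fold lower number (0.45 log units; beyond the scatter) from compound 3 to compound 4, 1.9-fold (0.29 log units) apart, within the scatter of two such steps

Adding ethyl to the chain, now with methoxy on the aromatic ring, gives a 6.3-fold higher number from compound 2 to compound 4 (0.80 log units; beyond the scatter), and this step carries over as well: the same change on two cores in this assay, a 12-fold higher number (1.09 log units; beyond the scatter) from compound 1 to compound 3 and a 6.3-fold higher number (0.80 log units; beyond the scatter) from compound 2 to compound 4, 1.9-fold (0.29 log units) apart, within the scatter of two such steps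

Across these four compounds, then, the two changes behave roughly independently of each other, with the longer chain giving the higher numbers on both aromatic rings, but this rests on a single pair of steps for each change and does not show that the same would hold for other groups or other cores.

The compounds shown leave open whether a chain longer than the one in compound 3 would raise the number further. They also leave open whether an amine or a carboxylic acid in place of the methoxy would fit the same pattern.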